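Replacing Methoxy with Hydroxy on a Cell-Killing Scaffold

This account rests on a few compounds, and the source may have more. Where it says the series, first, only, none or still open, it means among the compounds named here.

Of the compounds shown here, three have so far been measured in a functional assay on MCF7 cells (Homo sapiens) for cytotoxicity, read by sulforhodamine B assay, with a stated time of 48 h, tested at 0.01 uM; on this read-out higher numbers stand for a weaker effect at the one concentration tested and lower numbers for a stronger effect. Compound 1 `COc1cc(C)cc(-c2nn(CC#N)cc2-c2ccc(-c3cccc(C(C)=O)c3)nc2)c1` gives 97%, and compound 2 `Cc1cc(O)cc(-c2nn(CC#N)cc2-c2ccnc(-c3ccc(Oc4ccccc4)cc3)c2)c1` gives 92%; both are weak effects at the single concentration tested. Compound 3 `COc1cc(C)cc(-c2nn(CC#N)cc2-c2ccnc(-c3ccc(N(C)C)cc3)c2)c1` stands lowest of the three with 38%, a distance beyond the usual scatter from both companions, so it shows the strongest effect in this small group.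

Compound 4 `Cc1cc(O)cc(-c2nn(CC#N)cc2-c2ccnc(-c3ccc(N(C)C)cc3)c2)c1` has not yet been measured. It differs from compound 3 in one place: hydrogen in place of methyl on an oxygen on an aromatic ring. Compound 2 also carries a 3-hydroxy-5-methylphenyl ring, but its other aryl group differs from that of compound 3, so nothing in the measured set isolates the methoxy-to-hydroxy change on its own; compound 1 and compound 2 only show that two other aryl partners both sit high. With no direct comparison available, the change from compound 3 to compound 4 is expected to produce a modest step, leaning toward a somewhat weaker effect, though it could fall within the scatter. The estimate for compound 4 in this assay is 50%, within a range from 30% to 80%. The step implied by that estimate is expected to be a number 12 percentage points higher from compound 3 to compound 4 (beyond the scatter).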

Compound 4, a percentage reported as activity, at one concentration (the size of the read-out at that concentration, not a potency): 89%
For compound 4 the middle estimate is 39 percentage points below the measured one; the whole stated range lies below it.
By their numbers in this assay, from the lowest: compound 3; then compounds 4, 2 and 1 (each within the scatter of the next).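

In this assay, changing methoxy to hydroxy on the 3-methoxy-5-methylphenyl ring, with the rest of the molecule held constant, gives a number 51 percentage points higher from compound 3 to compound 4 (beyond the scatter). For the compounds shown here, this is the first direct reading of this change, and it shows that removing a single methyl from an oxygen on an aromatic ring is enough to lose most of the effect seen for compound 3. With hydroxy in place, dimethylamino in place of phenoxy on an aromatic carbon gives a number 3 percentage points lower from compound 2 to compound 4 (within the scatter), so in this pair the dimethylamino group does not by itself set the read-out apart.

No measurement shown gives a reason for the size of the methoxy-to-hydroxy step. As far as these compounds go, it remains open whether a longer chain on that oxygen, such as ethoxy, or an amine in place of the oxygen would keep the stronger effect of compound 3, and whether methoxy would make a similar difference alongside phenoxy.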